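Extending the Saturated Chain by One Methyl

The source may report more compounds than this note shows. Statements on the series, on what has been measured and on what is new or still open speak of the compounds shown alone.

Going by the values given here, compound 2 `CCCCCCCCCCCCCCCCCOC(=O)CCC(=O)N1CCN(CCCOc2cc3c(Nc4ccc(F)c(Cl)c4)ncnc3cc2OC)CC1` holds the higher of the two numbers so far recorded in a functional assay on A549 cells (Homo sapiens) for cytotoxicity, read by MTT assay, with a stated time of 24 h, tested at 60 uM (a lower number here means a stronger effect, a higher number a weaker effect of the compound at the concentration tested), where compound 2 gives 84.1%. Its nearest neighbour is compound 1 `CCCCCCCCCCCCCCCCOC(=O)CCC(=O)N1CCN(CCCOc2cc3c(Nc4ccc(F)c(Cl)c4)ncnc3cc2OC)CC1`, and in this assay compound 1 gives 80%. The two values lie within the scatter of each other, so they cannot be told apart. Compound 3 `CCCCCCCCCCCCCCCCCCOC(=O)CCC(=O)N1CCN(CCCOc2cc3c(Nc4ccc(F)c(Cl)c4)ncnc3cc2OC)CC1` differs from compound 2 by methyl in place of hydrogen on a saturated chain carbon, ten or more bonds along the chain from an oxygen next to a carbonyl group. Among the compounds with values here, only one measured step bears on this change, and it is the same kind of change: a number 4.1 percentage points higher from compound 1 to compound 2 (within the scatter), a step that stayed within the scatter. On that basis the expected step of a number 0.9 percentage points higher from compound 2 to compound 3 (within the scatter) in this assay is none beyond the scatter. Compound 3 is therefore estimated to give 85% in this assay, with a range from 72% to 96%.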

Compound 3, a percentage reported as activity, at one concentration (the size of the read-out at that concentration, not a potency): 87.2%
For compound 3 the middle estimate is 2.2 percentage points below the measured one, within the range that was stated.
By their numbers in this assay, from the lowest: compounds 1, 2 and 3 (each within the scatter of the next).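

In this assay the same methyl change, repeated at this position, gives a number 3.1 percentage points higher from compound 2 to compound 3 (within the scatter), and the ethyl in place of hydrogen gives a number 7.2 percentage points higher from compound 1 to compound 3 (within the scatter). Where a single step stood before, there are now two methyl steps and one ethyl step along this saturated chain, and none of them separates the compounds, so compounds 1, 2 and 3 cannot be told apart here. No supporting data bear on why these readings fall as they do.

The compounds shown leave open whether a much longer chain, or a shorter one, would give a step beyond the scatter in this assay. They also leave open whether an amine or a carboxylic acid in place of hydrogen on this chain carbon would do so.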